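The source may hold more compounds than are shown below. What is called first, only, known or untested is meant among the compounds shown, and "the series" means these compounds.

Measured so far:
- Compound 1, `CN(C)CCn1cnnc1-c1cc(Oc2ccc(NC(=O)N/N=C/c3c[nH]c4ccccc34)cc2F)ccn1`: 690 nM
- Compound 2, `COc1ccc(OC)c(/C=N/NC(=O)Nc2ccc(Oc3ccnc(-c4nncn4CCN(C)C)c3)c(F)c2)c1`: 6400 nM

In a functional assay on U-87MG ATCC cells (Homo sapiens) for cytotoxicity, read by MTT assay, with a stated time of 72 h (on this read-out lower numbers stand for stronger inhibition and higher numbers for weaker inhibition), compound 1 gives 690 nM, the lowest of the two numbers seen; compound 2 gives 6400 nM. Within the data shown here, the one measured step runs a 9.3-fold higher number from compound 1 to compound 2 (0.97 log units; beyond the scatter), so swapping the 1H-indol-3-yl for a dimethoxy-bearing phenyl cost potency by a modest amount.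

Compound 3, `COc1ccc(/C=N/NC(=O)Nc2ccc(Oc3ccnc(-c4nncn4CCN(C)C)c3)c(F)c2)cc1O`, is the next unmeasured member. Its change from compound 1 is 3-hydroxy-4-methoxyphenyl in place of 1H-indol-3-yl on a carbon with a double bond to nitrogen. The new group keeps one hydrogen-bond donor, as the 1H-indol-3-yl had, while adding two acceptors, and like compound 2 it replaces the two-ring group with a single six-membered ring. Among the measured compounds shown here, the only relevant step is the one from compound 1 to compound 2, which went upward beyond the scatter; the hydroxyl of compound 3 has no precedent here, so its effect is unknown. A weakening of similar, perhaps slightly smaller, size is expected. The estimate for compound 3 is 3000 nM in this assay, with a range of 1000 nM to 9000 nM, a step of a 4.3-fold higher number from compound 1 to compound 3 (0.64 log units; beyond the scatter).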

Compound 3, half-maximal inhibitory concentration: > 100000 nM
Compound 3: no number, only a limit (the forecaster's own chance of this, stated with the estimate: 5%); middle value at least 33-fold (1.52 log units) from the limit.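

Compound 3 gives no number in this assay, only a limit of the assay: the limit of > 100000 nM in this assay, at which 1 of the 3 values shown sits. On the carbon with a double bond to nitrogen, replacing 1H-indol-3-yl with a substituted phenyl can therefore cost far more than compound 2 suggested, since this change gives an at least 140-fold higher number from compound 1 to compound 3 (2.16 log units; beyond the scatter). The substituents on the phenyl ring also matter in their own right and not only the departure of the 1H-indol-3-yl, as exchanging one phenyl group for the other gives an at least 15-fold higher number from compound 2 to compound 3 (1.19 log units; beyond the scatter).

The compounds shown leave open which feature of the 3-hydroxy-4-methoxyphenyl group goes with the steep drop, the hydroxyl or the arrangement of the groups on the ring, and a plain phenyl or a 4-methoxyphenyl would help to separate these. They also leave open whether the indole nitrogen hydrogen matters for the stronger result of compound 1, a question that a 1-methylindol-3-yl group could address.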